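The compounds below may be only part of what the source reports. "The series", "measured", "known", "first", "only" and "open" are said of these compounds alone.

Measured so far in a functional assay on Jurkat cells (Homo sapiens) for cytotoxicity, with a stated time of 72 h; on this read-out higher numbers stand for an effect only at larger amounts of compound and lower numbers for an effect already at smaller amounts:
Compound 1 `COc1ccc(/C=C/[C@@](C)(/C=C/c2ccc(O)c(/C=C/C#N)c2)CCC=C(C)C)cc1`: > 49000 nM (a limit)
Compound 2 `CCOC(=O)/C=C/c1cc(/C=C/[C@](C)(/C=C/c2ccc(OC)cc2)CCC=C(C)C)ccc1O`: > 49000 nM (a limit)
Compound 3 `COc1ccc(/C=C/[C@@](C)(/C=C/c2ccc(O)c(/C=C/C(=O)OCc3ccccc3)c2)CCC=C(C)C)cc1`: > 49000 nM (a limit)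

Compound 3 has no number in this assay, only the limit > 49000 nM. The whole series stands at one place: the limit of > 49000 nM in this assay, at which 3 of the 3 values shown sit.

The next compound is compound 4 `COc1ccc(/C=C/[C@@](C)(/C=C/c2ccc(O)cc2)CCC=C(C)C)cc1`. The change is hydrogen in place of 2-(benzyloxycarbonyl)ethenyl on an aromatic carbon: the 2-(benzyloxycarbonyl)ethenyl group gives way to hydrogen on an aromatic carbon, ortho to a hydroxy group.

The measured steps that bear on this all vary the end of that same chain: a step that the two limits leave unreadable from compound 1 to compound 2, a step that the two limits leave unreadable from compound 1 to compound 3 and a step that the two limits leave unreadable from compound 2 to compound 3. None of them has a readable size, and none removes the chain. They therefore give no direction for the change in this assay, and no shift beyond the scatter can be argued from them.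

The expected result is an at least 1.0-fold lower number from compound 3 to compound 4 (0.03 log units; that floor lies within the scatter), which is an estimate of no real movement from the limit. For compound 4 the estimated value is 45000 nM, with an expected range from 15000 nM to 90000 nM.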

Compound 4, half-maximal effective concentration: > 49000 nM
Compound 4 was reported as a limit; the forecaster's own chance of this, stated with the estimate: 65%; middle value at least 1.0-fold (0.03 log units) from the limit.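

In this assay compound 4 gives only a limit, > 49000 nM, so none of its steps from compound 1, compound 2 or compound 3 can be read. The compounds shown leave open whether the chain on the aromatic carbon, or its removal, affects the result in this assay at all: the limit of > 49000 nM in this assay, at which 4 of the 4 values shown sit.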